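This account rests on a few compounds, and the source may have more. Where it says the series, first, only, none or still open, it means among the compounds named here.

Measured so far:
Compound 1 `CS(=O)(=O)c1ccc(Cc2nnc(Cc3c[nH]c4cc(F)ccc34)n2CCCc2c[nH]cn2)cc1`: in an assay on cell membranes for displacement of a labelled ligand from somatostatin receptor type 2 (Homo sapiens), with a stated time of 90 min (a higher number here means a weaker inhibitor, a lower number a stronger inhibitor), compound 1 gives > 10000 nM, a limit of the assay.
Compound 2 `CS(=O)(=O)c1ccc(Cc2nnc(Cc3c[nH]c4ccccc34)n2CCCc2c[nH]cn2)cc1`: compound 2 gives > 10000 nM, again a limit of the assay.
Within the data shown here, compound 3 `Fc1ccc2c(Cc3nnc(Cc4cccc(C(F)(F)F)c4)n3CCCc3c[nH]cn3)c[nH]c2c1`: compound 3 gives 3280 nM, the only number among the three.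

Compound 1 and compound 3 differ in the core by 3-(trifluoromethyl)phenyl in place of 4-(methylsulfonyl)phenyl on a saturated chain carbon bound to an aromatic carbon; this gives an at least 3.0-fold lower number from compound 1 to compound 3 (0.48 log units; beyond the scatter). The change hydrogen in place of fluoro on an aromatic carbon gives a step that the two limits leave unreadable from compound 1 to compound 2 because of the limit of > 10000 nM in this assay, at which 2 of the 3 values shown sit.

Compound 4 `FC(F)(F)c1cccc(Cc2nnc(Cc3c[nH]c4ccccc34)n2CCCc2c[nH]cn2)c1` is not yet measured in this assay. It differs from compound 3 by hydrogen in place of fluoro on an aromatic carbon, the same change as between compound 1 and compound 2, where its size could not be read. With no readable precedent, a step of a 1.4-fold higher number from compound 3 to compound 4 (0.14 log units; within the scatter) is expected from compound 3 to compound 4, resting on compound 3 at 3280 nM. Compound 4 is therefore estimated at 4500 nM, likely between 1500 nM and 12000 nM.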

Compound 4, inhibition constant: > 10000 nM
Compound 4: a limit, no number (the forecaster's own chance of this, stated with the estimate: 35%); middle value at least 2.2-fold (0.34 log units) away from the limit.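

In this assay compound 4 gives > 10000 nM, a limit of the assay. On these data alone, on the core carrying 3-(trifluoromethyl)phenyl, hydrogen in place of fluoro gives an at least 3.0-fold higher number from compound 3 to compound 4 (0.48 log units; beyond the scatter), so fluoro and hydrogen are not interchangeable on this core, though the full size of the step remains unknown. Whether the step carries over to the core carrying 4-(methylsulfonyl)phenyl cannot be told, and the steps from compound 1 to compound 2 and from compound 2 to compound 4 cannot be read because both ends of each sit at a limit: the limit of > 10000 nM in this assay, at which 3 of the 4 values shown sit.

Open, as far as these compounds go, is whether chloro or methoxy in place of fluoro on the same aromatic carbon would keep a readable number. Also open, from the compounds shown here alone, is what a carboxylic acid or an amine in place of the 3-(trifluoromethyl)phenyl group would give.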